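The source may report more compounds than this note shows. Statements on the series, on what has been measured and on what is new or still open speak of the compounds shown alone.

Of the compounds shown here, two built on one shared core have so far been measured in a functional assay on Ehrlich cells (Mus musculus) for cytotoxicity, tested at 25 ug/mL; a lower number here means a weaker effect, a higher number a stronger effect of the compound at the concentration tested. Compound 1, `COc1cc(N2C(N)=C(C#N)C(c3c(OC)ccc4ccccc34)C3=C2CC(C)(C)CC3=O)cc(OC)c1OC`, gives 5% in this assay. Compound 2, `COc1cc(N2C(N)=C(C#N)C(c3ccccc3)C3=C2CC(C)(C)CC3=O)cc(OC)c1OC`, gives 6% in this assay. For the measured compounds named here, the one step between them, a number 1 percentage points higher from compound 1 to compound 2 (within the scatter), is within the scatter, so the two numbers cannot be told apart. On the numbers shown, compound 2 stands at the top of the pair, but with compound 1 sitting within the scatter of it.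

Compound 3, `COc1cc(N2C(N)=C(C#N)C(c3ccc(O)cc3)C3=C2CC(C)(C)CC3=O)cc(OC)c1OC`, has not yet been measured. It differs from compound 2 in a single place: hydroxy in place of hydrogen on an aromatic carbon. Going by the values given here, only one measured step bears on this change, the one that also alters the group on the saturated ring carbon, and that step, a number 1 percentage points higher from compound 1 to compound 2 (within the scatter), stayed within the scatter although it exchanged a whole 2-methoxynaphthalen-1-yl for a phenyl, a far larger change than adding one hydroxy. Nothing here points in either direction, so no step beyond the scatter is expected in this assay. Compound 3 is therefore estimated at 6%, with a range from 0% to 16%. The expected step is thus no change at the digits printed from compound 2 to compound 3 (within the scatter).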

Compound 3, a percentage reported as activity, at one concentration (the size of the read-out at that concentration, not a potency): 20%
Beside the measured number, compound 3's estimate is 14 percentage points below it; measured number outside the range, above it.
By their numbers in this assay, from the lowest: compounds 1 and 2 (each within the scatter of the next); then compound 3.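

In this assay, the para position of the phenyl ring on the saturated ring carbon proves sensitive to a very small edit: adding hydroxy in place of hydrogen gives a number 14 percentage points higher from compound 2 to compound 3 (beyond the scatter) even though only one heavy atom enters. The larger exchange of the whole 2-methoxynaphthalen-1-yl for 4-hydroxyphenyl gives a number 15 percentage points higher from compound 1 to compound 3 (beyond the scatter) while the exchange for plain phenyl gave a number 1 percentage points higher from compound 1 to compound 2 (within the scatter), so among these three compounds, only the one carrying the hydroxy stands apart, and its rise is still modest. No measurement is available that explains why this hydroxy changes the number.

Going by these compounds, it remains open whether this rise is specific to hydroxy or would also appear with an amine or a carboxylic acid at the same place, and whether a hydroxy on another carbon of the ring would behave alike. The compounds shown also leave open how the effect changes with concentration, as each number is the size of the read-out at a single concentration and not a potency.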